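Trimming the Benzyloxy Chain in a Kinase Series

The compounds below may be only part of what the source reports. "The series", "measured", "known", "first", "only" and "open" are said of these compounds alone.

Compound 2 `O=C1NCc2c1c1c(c3c2c2ccccc2n3CCO)CCc2cc(OCCOCc3ccccc3)ccc2-1` gives 0% in an assay on isolated protein for inhibition of mitogen-activated protein kinase kinase kinase 11 (Homo sapiens), tested at 1 uM (on this read-out higher numbers stand for more inhibition at the one concentration tested (going by the name of the read-out) and lower numbers for less inhibition), the lowest of the two numbers measured; compound 1 `O=C1NCc2c1c1c(c3c2c2ccccc2n3CCO)CCc2cc(OCC3CC3)ccc2-1` gives 32%. Going by the values given here, the only measured step, a number 32 percentage points lower from compound 1 to compound 2 (beyond the scatter), is large and went with cyclopropyl giving way to (benzyloxy)methyl. Compound 3 `COCCOc1ccc2c(c1)CCc1c-2c2c(c3c4ccccc4n(CCO)c13)CNC2=O` differs from compound 2 by hydrogen in place of phenyl on a saturated chain carbon bound to an oxygen on a saturated carbon, so the chain is shortened again. Among the compounds with values here, no measured step matches this change, and the single large step is only an indirect guide, so a partial return toward the level of compound 1 is expected for compound 3, a number 15 percentage points higher from compound 2 to compound 3 (beyond the scatter). Compound 3 is estimated at 15%, within 0% to 40%.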

Compound 3, a percentage reported as inhibition, at one concentration (the size of the read-out at that concentration, not a potency): 40%
For compound 3 the middle estimate is 25 percentage points below the measured one, within the range that was stated.
By their numbers in this assay, from the lowest: compound 2; then compounds 1 and 3 (each within the scatter of the next).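

With hydrogen in place of phenyl on a saturated chain carbon bound to an oxygen on a saturated carbon, the read-out in this assay shows a number 40 percentage points higher from compound 2 to compound 3 (beyond the scatter), so the loss belongs to the benzyloxy end and not to the chain as a whole. Methoxymethyl in place of cyclopropyl gives a number 8 percentage points higher from compound 1 to compound 3 (within the scatter), so these two groups cannot be told apart here. Nothing available explains why the phenyl costs so much. On these data alone, whether a terminal amine, a carboxylic acid or a longer chain ending in methoxy would hold this level remains open.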